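Ester chain extension and growth inhibition

The compounds below may be only part of what the source reports. "The series", "measured", "known", "first", "only" and "open" are said of these compounds alone.

Compound 1 `C=C[C@@](C)(/C=C/c1ccc(OC(C)=O)cc1)CCC=C(C)C` gives 81% in a functional assay on THP-1 cells (Homo sapiens) for inhibition, with a stated time of 48 h, tested at 50 uM; on this read-out lower numbers stand for less inhibition of growth and higher numbers for more inhibition of growth at the one concentration tested. Compound 2 `C=C[C@@](C)(/C=C/c1ccc(OC(=O)CCC)cc1)CCC=C(C)C` stands second highest of the three measured numbers, giving 54%, while compound 3 `C=C[C@@](C)(/C=C/c1ccc(OC(=O)CCCC)cc1)CCC=C(C)C` gives 15%. Compound 4 `C=C[C@@](C)(/C=C/c1ccc(OC(=O)CCCCCCC)cc1)CCC=C(C)C` is not yet measured; it differs from compound 2 by butyl in place of hydrogen on a saturated chain carbon, three bonds along the chain from a carbonyl carbon. The measured step at the same place is a number 39 percentage points lower from compound 2 to compound 3 (beyond the scatter), and the chain extensions in a number 27 percentage points lower from compound 1 to compound 2 (beyond the scatter) and a number 66 percentage points lower from compound 1 to compound 3 (beyond the scatter) run in the same direction, each beyond the scatter. A further large fall is therefore expected for compound 4 in this assay, with the read-out unable to go much lower than the number of compound 3. Compound 4 is estimated at 8%, within 0% to 30%. The step expected here is a number 46 percentage points lower from compound 2 to compound 4 (beyond the scatter).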

Compound 4, percent growth inhibition at one concentration: 62%
Compound 4: middle estimate off by 54 percentage points, on the low side; measured number outside the range, above it.
By their numbers in this assay, from the lowest: compound 3; then compounds 2 and 4 (each within the scatter of the next); then compound 1.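

In this assay the fall with chain length does not continue: there is a number 47 percentage points higher from compound 3 to compound 4 (beyond the scatter). The run of falling numbers ends at compound 3, and compound 3 goes against any steady trend. Butyl in place of hydrogen at this place gives a number 8 percentage points higher from compound 2 to compound 4 (within the scatter) but still leaves a number 19 percentage points lower from compound 1 to compound 4 (beyond the scatter) as the gap to the acetate ester. No measurement shown bears on why the read-out turns at this position. On these data alone, it remains open whether a longer chain would hold this number or lose it, and what a terminal carboxylic acid on the chain would do.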